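Fluoro to Methoxy on a Cytotoxicity Read-out

A few compounds are considered here, and "the series" means these few. Any claim that something is new, unique, unknown or untested is made for them only; others in the source may bear on it.

Compound 2 `Fc1ccc(-c2cc(-c3ccc4cc(F)ccc4n3)n(-c3ccc(F)cc3)n2)cc1` was tested in an ADME assay on Huh-7 cells (Homo sapiens) for cytotoxicity, read by XTT assay, with a stated time of 3 days, tested at 200 uM (on this read-out higher numbers stand for a weaker effect at the one concentration tested and lower numbers for a stronger effect), where compound 2 gives 86.5%. For the measured compounds named here, its one measured neighbour is compound 1 `Fc1ccc(-n2nc(-c3ccccc3)cc2-c2ccc3cc(F)ccc3n2)cc1`; in this assay compound 1 gives 91.6%. Of the two numbers, compound 2 stands nearest to compound 1, and the step of a number 5.1 percentage points lower from compound 1 to compound 2 (within the scatter) lies within the scatter, so the two read as the same. The unmeasured compound 3 `COc1ccc(-c2cc(-c3ccc4cc(F)ccc4n3)n(-c3ccc(F)cc3)n2)cc1` differs from compound 2 in one place: methoxy in place of fluoro on an aromatic carbon. Going by the values given here, no measured step exchanges fluoro for methoxy; the only step known, from a fluoro in place of hydrogen, was small. On that basis compound 3 is expected to show no movement beyond the scatter in this assay, and the expected step of a number 0.5 percentage points higher from compound 2 to compound 3 (within the scatter) is therefore slight. Compound 3 is estimated at 87%, with a range from 70% to 100%.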

Compound 3, a percentage reported as activity, at one concentration (the size of the read-out at that concentration, not a potency): 95.4%
Estimate against measurement, compound 3: 8.4 percentage points below; low and high end bracket the measured number.
By their numbers in this assay, from the lowest: compounds 2, 1 and 3 (each within the scatter of the next).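

The methoxy group at this position gives a number 8.9 percentage points higher from compound 2 to compound 3 (within the scatter) in this assay, and measured against the unsubstituted phenyl it gives a number 3.8 percentage points higher from compound 1 to compound 3 (within the scatter). Hydrogen, fluoro and methoxy at this position therefore read as the same, so the flat result seen on going from hydrogen to fluoro also holds for a group that brings oxygen and a hydrogen-bond acceptor. Nothing available explains this flat result. From the compounds shown here alone, it remains open whether an amine or a carboxylic acid at this position would also read the same, or would move the number beyond the usual scatter. With only a single concentration shown, the compounds also leave open whether the three would still read as the same at other concentrations.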